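Replacing 3-Fluorophenyl with 1H-Indol-6-yl: An Estimate

The compounds below may be only part of what the source reports. "The series", "measured", "known", "first", "only" and "open" are said of these compounds alone.

Measured so far:
Compound 1, `COc1cc(-c2cccc3nc(-c4cccc(F)c4)oc23)cc(OC)c1OC`, 3300 nM in a functional assay on NCI-H460 cells (Homo sapiens) for antiproliferative activity, read by MTT assay, with a stated time of 48 h; on this read-out higher numbers stand for weaker inhibition and lower numbers for stronger inhibition
Compound 2, `COc1cc(-c2cccc3nc(-c4cccc(O)c4)oc23)cc(OC)c1OC`, 1900 nM in this assay

Compound 1 has the higher of the two numbers, with compound 2 nearest: a 1.7-fold lower number from compound 1 to compound 2 (0.24 log units; within the scatter). Compound 3, `COc1cc(-c2cccc3nc(-c4ccc5cc[nH]c5c4)oc23)cc(OC)c1OC`, is not yet measured. It differs from compound 1 by 1H-indol-6-yl in place of 3-fluorophenyl on an aromatic carbon. Going by the values given here, the only step with some bearing is the one from compound 1 to compound 2, where hydroxy replaced fluoro on an aromatic carbon and the number stayed within the scatter. Among the compounds with values here, the 1H-indol-6-yl group is a larger change, also bringing 1 hydrogen-bond donor, but no measured pair covers it. Compound 3 is therefore expected near compound 1 in this assay, with at most a small step: a 1.5-fold lower number from compound 1 to compound 3 (0.18 log units; within the scatter). The estimate for compound 3 is 2200 nM, with a range from 700 nM to 7000 nM.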

Compound 3, half-maximal inhibitory concentration: 24 nM
For compound 3 the middle estimate is 92-fold (1.96 log units) above the measured one; measured number below the stated range.
By their numbers in this assay, from the lowest: compound 3; then compounds 2 and 1 (each within the scatter of the next).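

With 1H-indol-6-yl in place of 3-fluorophenyl there is a 140-fold lower number from compound 1 to compound 3 (2.14 log units; beyond the scatter) and with it in place of 3-hydroxyphenyl there is a 79-fold lower number from compound 2 to compound 3 (1.90 log units; beyond the scatter) in this assay at this aromatic carbon of the shared core. This position, which showed no change beyond the scatter when hydroxy replaced fluoro, can therefore respond strongly when the whole ring group changes. No measurement shown here explains the size of this gain.

From the compounds shown here alone, it remains open whether the indole nitrogen with its hydrogen matters, which a 2-naphthyl group, with carbon in its place, would test. A 1H-indol-5-yl group would show whether the point of attachment on the indole matters too.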